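The source may hold more compounds than are shown below. What is called first, only, known or untested is meant among the compounds shown, and "the series" means these compounds.

Of the compounds shown here, two have been measured in a functional assay (Homo sapiens) for inhibition of Nucleic Acid, tested at 100 uM; a higher number here means more inhibition at the concentration tested (going by the name of the read-out), a lower number less inhibition. Compound 1 `[N-]=[N+]=Nc1nccc2c1ncn2[C@H]1C[C@H](O)[C@@H](CO)O1` gives 4%. Compound 2 `CSc1nccc2c1ncn2C1O[C@H](CO)[C@@H](O)[C@H]1O` gives 24%, the higher of the two numbers, with compound 1 lying below it by a gap beyond the usual scatter. Compound 3 `CCNc1nccc2c1ncn2C1O[C@H](CO)[C@@H](O)[C@H]1O` is not yet measured; it differs from compound 2 in one place: ethylamino in place of methylsulfanyl on an aromatic carbon. Going by the values given here, no measured pair shows a change of this kind, so its effect is unknown. A step within the scatter of this assay, in either direction, is expected here, that is a number 4 percentage points lower from compound 2 to compound 3 (within the scatter). On that basis compound 3 is estimated at 20%, with a range from 0% to 45%.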

Compound 3, a percentage reported as inhibition, at one concentration (the size of the read-out at that concentration, not a potency): 4%
Compound 3: the middle estimate sits 16 percentage points above what was measured, within the range that was stated.
By their numbers in this assay, from the lowest: compounds 1 and 3 (each within the scatter of the next); then compound 2.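

Replacing methylsulfanyl with ethylamino on the aromatic carbon next to the ring nitrogen gives, in this assay, a number 20 percentage points lower from compound 2 to compound 3 (beyond the scatter). This shows that the read-out responds to the group at this position while the rest of the structure stays the same, with methylsulfanyl the better of the two groups. Nothing available bears on the reason for this difference.

As far as these compounds go, whether an unsubstituted amine, a methoxy group or a longer alkylamino chain at this carbon would match compound 2 remains open. Also open, from the compounds shown here alone, is whether the change in the linking atom or the change in chain length accounts for the step, as the two vary together here.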